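Compound 3 to compound 4: the 4-hydroxycyclohexyl swap

The compounds below may be only part of what the source reports. "The series", "measured", "known", "first", "only" and "open" are said of these compounds alone.

In a physicochemical assay for lipophilicity (on this read-out lower numbers stand for lower lipophilicity and higher numbers for higher lipophilicity), compound 3 (`CNC(=O)c1cc(C(=O)N[C@H]2[C@@H]3C[C@@H](O)C[C@@H]32)c([C@@H](C)c2ccccc2)o1`) reads 2.8 and is the lowest of the three numbers at hand. Compound 2 (`CNC(=O)c1cc(C(=O)N[C@H]2CC[C@H](O)CC2)c([C@@H](C)c2ccc(Cl)cc2)o1`) stands at 3.5 and compound 1 (`CNC(=O)c1cc(C(=O)N[C@H]2[C@@H]3COC[C@@H]32)c([C@@H](C)c2ccccc2)o1`) at 4.1 on the same scale.

Compound 4 (`CNC(=O)c1cc(C(=O)N[C@H]2CC[C@H](O)CC2)c([C@@H](C)c2ccccc2)o1`) is still unmeasured. The change from compound 3 is a group of 7 heavy atoms (6 carbon, 1 oxygen; one six-membered non-aromatic ring of carbon only) in place of a group of 7 heavy atoms (6 carbon, 1 oxygen; one three-membered non-aromatic ring of carbon only, one five-membered non-aromatic ring of carbon only), on an amide-type nitrogen and the group that enters is 4-hydroxycyclohexyl.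

One measured step falls at this amide-type nitrogen: a number 1.30 log units lower from compound 1 to compound 3 (beyond the scatter) and it is large and beyond the scatter. A change at this place can therefore move the number a long way. That step starts from a different group, however, so its size does not carry over to the present change.

The closer guide is compound 2 at 3.5 with the same 4-hydroxycyclohexyl group, although it also carries a chlorine that compound 4 lacks. Among the measured compounds shown here, no measured step isolates that chlorine. A number for compound 4 is expected near that of compound 3 and under that of compound 2.

The expected change is a number 0.20 log units higher from compound 3 to compound 4 (within the scatter) and it is not expected to exceed the scatter. For compound 4 the estimate is 3 (expected range 2.6 to 3.4).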

Compound 4, distribution coefficient: 2.8
Beside the measured number, compound 4's estimate is 0.20 log units above it; the range from low to high includes it.
By their numbers in this assay, from the lowest: compounds 3 and 4 (each within the scatter of the next); then compound 2; then compound 1.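

In this assay, 4-hydroxycyclohexyl on the amide-type nitrogen, in place of the group carrying a three-membered and a five-membered carbon ring, gives no change at the digits printed from compound 3 to compound 4 (within the scatter), so this position tolerates this exchange of ring type without a readable shift in the number. Both groups also stand at the same distance from compound 1: a number 1.30 log units lower from compound 1 to compound 3 (beyond the scatter) and a number 1.30 log units lower from compound 1 to compound 4 (beyond the scatter), so the large step seen earlier is not tied to a single entering group. The series also gains its first isolated reading on the aromatic carbon, where hydrogen in place of chloro gives a number 0.70 log units lower from compound 2 to compound 4 (beyond the scatter), a change beyond the scatter at a place away from the amide-type nitrogen.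

Nothing among the data at hand bears on what lies behind these numbers. Still open, as far as these compounds go, are whether the chloro step holds with the other group on the amide-type nitrogen, and whether an amine or a carboxylic acid on the ring of that group would leave the number where compound 3 and compound 4 sit.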